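Pyridyl Ether in Place of Fluorophenyl: Expected Microsomal Half-Life

The source may report more compounds than this note shows. Statements on the series, on what has been measured and on what is new or still open speak of the compounds shown alone.

Compound 2 `Cc1nc(C)c([C@H](OC(C)(C)C)C(=O)O)c(N2CCC(C)(C)CC2)c1-c1ccc(OCCCc2ccc(F)cc2)cc1` stands in an ADME assay on microsomes from liver (Homo sapiens) for metabolic stability, read by LC-MS, tested at 0.5 uM (on this read-out lower numbers stand for a shorter-lived compound and higher numbers for a longer-lived compound), at > 2 h, which is a limit of the assay rather than a number. Compound 1 `Cc1nc(C)c([C@H](OC(C)(C)C)C(=O)O)c(N2CCC(C)(C)CC2)c1-c1ccc(OCCc2cc(F)c(F)cc2F)cc1` likewise gives in this assay a limit of > 2 h. Compound 3 `Cc1nc(C)c([C@H](OC(C)(C)C)C(=O)O)c(N2CCC(C)(C)CC2)c1-c1ccc(SCCc2ccc(F)cc2)cc1` also gives in this assay a limit of > 2 h. All three therefore share (the limit of > 2 h in this assay, at which 3 of the 3 values shown sit). The step from compound 1 to compound 2 reads a step that the two limits leave unreadable from compound 1 to compound 2, the step from compound 2 to compound 3 reads a step that the two limits leave unreadable from compound 2 to compound 3, and the step from compound 1 to compound 3 reads a step that the two limits leave unreadable from compound 1 to compound 3. Compound 4 `Cc1nc(C)c([C@H](OC(C)(C)C)C(=O)O)c(N2CCC(C)(C)CC2)c1-c1ccc(OCCc2ccccn2)cc1` carries, relative to compound 2, (pyridin-2-yl in place of 4-fluorobenzyl on a saturated chain carbon, two bonds along the chain from an oxygen on an aromatic ring). The measured steps that bear on this change are unreadable, so no step beyond the scatter in either direction is expected in this assay. Compound 4 is therefore estimated at 2 h, between 0.8 h and 4 h. This amounts to an expected step of a number no higher from compound 2 to compound 4 (the limit leaves the size open).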

Compound 4, half-life: 0.5 h
Compound 4: middle estimate off by 4.0-fold (0.60 log units), on the high side; measured number below the stated range.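

In this assay, within the data shown here, the step to pyridin-2-yl on this chain is the first that can be read, though only as a bound, and it gives an at least 4.0-fold lower number from compound 2 to compound 4 (0.60 log units; beyond the scatter) and also an at least 4.0-fold lower number from compound 3 to compound 4 (0.60 log units; beyond the scatter) in the same direction. Compound 1 already carries the ethoxy chain of compound 4, and the ring change alone still gives an at least 4.0-fold lower number from compound 1 to compound 4 (0.60 log units; beyond the scatter) so the fall does not depend on chain length.

On these data alone, the true size of these steps stays open. So does whether plain phenyl or pyridin-3-yl on the same chain would behave like pyridin-2-yl.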